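Swapping a Hydroxyl for a Methylsulfonyl Group

The source may hold more compounds than are shown below. What is called first, only, known or untested is meant among the compounds shown, and "the series" means these compounds.

Compound 1, `N#Cc1c(Cn2c(=O)n(C3CC3)c3ccncc32)nc2cc(Cl)ccn12`: in an ADME assay on HEp-2 cells (Homo sapiens) for cytotoxicity, read by CCK-8 assay, with a stated time of 6 days (on this read-out lower numbers stand for higher toxicity in this test and higher numbers for lower toxicity in this test), compound 1 gives 22500 nM.
Compound 2, `O=C(NCCO)c1c(Cn2c(=O)n(C3CC3)c3ccncc32)nc2cc(Cl)ccn12`: in this assay compound 2 gives only a limit, > 100000 nM.

Compound 2 does not yield a firm number in this test: its value sits at the limit of > 100000 nM in this assay, at which 1 of the 2 values shown sits, so only a floor is known for it. Among the compounds with values here, the single measured step, an at least 4.4-fold higher number from compound 1 to compound 2 (0.64 log units; beyond the scatter), runs from a firm number up to that limit. Compound 3, `CS(=O)(=O)CCNC(=O)c1c(Cn2c(=O)n(C3CC3)c3ccncc32)nc2cc(Cl)ccn12`, differs from compound 2 by methylsulfonyl in place of hydroxy on a saturated chain carbon, two bonds along the chain from an amide-type nitrogen. Within the data shown here, no measured pair shows this particular swap; the measured step concerns a different change at a different place and says nothing directly about the methylsulfonyl group. Among the measured compounds shown here, the only guide is that compound 2 already reads as a limit. Compound 3 is therefore expected to show a step of a number no higher from compound 2 to compound 3 (the limit leaves the size open), within the usual scatter. In this assay compound 3 is estimated at 100000 nM, with a range from 45000 nM to 220000 nM, and quite possibly again reported only as a limit.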

Compound 3, half-maximal cytotoxic concentration: > 100000 nM
Compound 3 gave a limit, no number; the forecaster's own chance of this, stated with the estimate: 70%; the middle value lies on the limit itself.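

In this assay the hydroxy of compound 2 can give way to methylsulfonyl on this chain, and the reading is still only a limit. The (2-(methylsulfonyl)ethyl)carbamoyl group in place of the nitrile gives an at least 4.4-fold higher number from compound 1 to compound 3 (0.64 log units; beyond the scatter), so the rise over compound 1 does not depend on the hydroxy alone. The step between compound 2 and compound 3 cannot be read, because both sit at the same limit: the limit of > 100000 nM in this assay, at which 2 of the 3 values shown sit.

Going by these compounds, how far the true values of compound 2 and compound 3 lie past this limit stays unknown, so the two groups cannot be ranked. On these data alone, it also stays open whether an amine or a carboxylic acid in place of hydroxy on a saturated chain carbon would stay at the limit or give a firm number.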